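A few compounds are considered here, and "the series" means these few. Any claim that something is new, unique, unknown or untested is made for them only; others in the source may bear on it.

Two members of this series have a number in an ADME assay on cells (Hepatocyte, Rattus norvegicus) for metabolic stability, with a stated time of 90 min; a higher number here means faster removal of the compound, a lower number slower removal. Compound 1, `CCC(CC)CNc1c(C(N)=O)cnc2ccc(C#N)cc12`, gives 74 uL/min. Compound 2, `NC(=O)c1cnc2ccc(-c3cccnc3)cc2c1SC1CCCC1`, gives 120 uL/min. Among the compounds with values here, compound 2 is the one whose number stands higher of the two, but the gap to compound 1 lies within the usual scatter of this assay, so the two compounds cannot be separated on these numbers. Within the data shown here, no step between measured compounds has been computed.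

The next compound, compound 3, `NC(=O)c1cnc2ccc(-c3cccnc3)cc2c1NCC1CCCCC1`, has not yet been measured in this assay. It differs from compound 2 in one place: (cyclohexylmethyl)amino in place of cyclopentylsulfanyl on an aromatic carbon. The new substituent on the shared core brings a secondary amine of the same kind as that in compound 1, and compound 1 sits within the scatter of compound 2.

On this basis the step from compound 2 to compound 3 is expected to be a 1.3-fold lower number from compound 2 to compound 3 (0.12 log units; within the scatter), that is, no change beyond the scatter, with a slight lean toward slower removal. Compound 3 is therefore estimated at 90 uL/min in this assay, with a range from 45 uL/min to 180 uL/min.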

Compound 3, intrinsic clearance in a liver preparation (reported as CLH), per the amount of preparation that the assay uses: 130 uL/min
Compound 3: the middle estimate sits 1.4-fold (0.16 log units) below what was measured; the measured number falls inside the stated range.
By their numbers in this assay, from the lowest: compounds 1, 2 and 3 (each within the scatter of the next).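

At this position, on an aromatic carbon ortho to a carbamoyl group and opposite the ring nitrogen, this assay now has its first comparison of compounds that differ in one place: (cyclohexylmethyl)amino in place of cyclopentylsulfanyl gives a 1.1-fold higher number from compound 2 to compound 3 (0.03 log units; within the scatter). Within the data shown here, this exchange replaces a sulfur link with a nitrogen link, brings in a hydrogen-bond donor and replaces a five-membered carbon ring with a six-membered one, yet these differences together produce no step that can be separated from the scatter. No measurement in hand explains this result.

As far as these compounds go, both groups compared here carry a non-aromatic carbon ring, so it remains open whether a group without such a ring, such as a carboxylic acid or a short chain ending in a hydroxyl group, would give a step beyond the scatter at this position. Compound 1 differs from compound 2 and compound 3 in more than one place, so it cannot show how the remainder of the shared core contributes to the number in this assay.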